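Stability notes: triazole isomer swap on compound 2

A few compounds are considered here, and "the series" means these few. Any claim that something is new, unique, unknown or untested is made for them only; others in the source may bear on it.

Measured so far in an ADME assay on microsomes from liver (Homo sapiens) for metabolic stability; a higher number here means that the compound lasts longer, a lower number that the compound disappears faster:
- compound 1 `CC(C)NC(=O)CC(c1ccc(-c2ccc3cccc(F)c3c2)[nH]c1=O)C(C)C`: 0.32 h
- compound 2 `CCn1ncc2c(F)cc(-c3ccc(C(CC)(CC)c4ncn(C)n4)c(=O)[nH]3)cc21`: > 3 h
- compound 3 `CC(C)C(/C=C1/CCNC1=O)c1ccc(-c2ccc3cccc(F)c3c2)[nH]c1=O`: 0.987 h

Going by the values given here, compound 2 reaches the upper limit of this assay, so its value is a limit and not a number; it is the one value among the three that sits at the limit of > 3 h in this assay, at which 1 of the 3 values shown sits. Among the compounds with values here, compounds 1 and 3 share a different core, and the step of a 3.1-fold higher number from compound 1 to compound 3 (0.49 log units; beyond the scatter) is the only measured change.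

Compound 4 `CCn1ncc2c(F)cc(-c3ccc(C(CC)(CC)c4nncn4C)c(=O)[nH]3)cc21` is the next compound. It differs from compound 2 by 4-methyl-4H-1,2,4-triazol-3-yl in place of 1-methyl-1H-1,2,4-triazol-3-yl on a saturated chain carbon bound to an aromatic carbon and two saturated chain carbons. Within the data shown here, no measured step touches this kind of change; the step from compound 1 to compound 3 alters a different part of a different core and does not bear on it. The atoms are unchanged, and with compound 2 already at the limit, no step beyond the scatter is expected. For compound 4 the expected step is a number no higher from compound 2 to compound 4 (the limit leaves the size open), and the estimate for compound 4 is 3 h, in the range 1.5 h to 6 h, with a fair chance that this assay again reports only a limit.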

Compound 4, half-life: 2.67 h
Estimate against measurement, compound 4: 1.1-fold (0.05 log units) above; low and high end bracket the measured number.
By their numbers in this assay, from the lowest: compound 1; then compound 3; then compound 4. At a limit, above all of these: compound 2.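

Compound 2 stands at a limit and not at a number in this assay: the limit of > 3 h in this assay, at which 1 of the 4 values shown sits. Going by these compounds alone, with 4-methyl-4H-1,2,4-triazol-3-yl in place of 1-methyl-1H-1,2,4-triazol-3-yl on a saturated chain carbon bound to an aromatic carbon and two saturated chain carbons, compound 4 gives the first true number for this core in this assay, 2.67 h. The step reads an at least 1.1-fold lower number from compound 2 to compound 4 (0.05 log units; that floor lies within the scatter), so the swap of triazole isomers has no shown effect beyond the scatter, though the limit leaves the true size of the step open.

The compounds shown leave open how this assay responds when a group other than a methyl triazole, such as a nitrile or a primary amide, stands at this place. Also open, on these data alone, is whether a longer chain in place of the methyl on the triazole would move the number.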